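This account rests on a few compounds, and the source may have more. Where it says the series, first, only, none or still open, it means among the compounds named here.

Compound 1 `COc1cc2c(Oc3ccc(NC(=O)c4cc(-c5ccccc5F)ccn4)cc3F)ccnc2cc1OCCCN1CCCCC1` is the reference point of this set. In a functional assay on NCI-H460 cells (Homo sapiens) for cytotoxicity, read by MTT assay, with a stated time of 72 h (on this read-out higher numbers stand for weaker inhibition and lower numbers for stronger inhibition), compound 1 gives 130 nM. Compound 2 `COc1cc2c(Oc3ccc(NC(=O)c4cc(-c5ccc(C(F)(F)F)cc5)ccn4)cc3F)ccnc2cc1OCCCN1CCCCC1` differs from it only in one group, (4-(trifluoromethyl)phenyl in place of 2-fluorophenyl on an aromatic carbon), and in this assay compound 2 gives 360 nM; the step of a 2.8-fold higher number from compound 1 to compound 2 (0.44 log units; beyond the scatter) is a modest weakening. Compound 3 `COc1cc2c(Oc3ccc(NC(=O)c4cc(-c5ccccc5F)ccn4)cc3F)ccnc2cc1OCCCN1CCCC1` carries the other change, (pyrrolidin-1-yl in place of piperidin-1-yl on a saturated chain carbon, three bonds along the chain from an oxygen on an aromatic ring), and in this assay compound 3 gives 140 nM; the step of a 1.1-fold higher number from compound 1 to compound 3 (0.03 log units; within the scatter) shows that the two values cannot be told apart on this read-out.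

Compound 4 `COc1cc2c(Oc3ccc(NC(=O)c4cc(-c5ccc(C(F)(F)F)cc5)ccn4)cc3F)ccnc2cc1OCCCN1CCCC1` has not yet been measured in this assay. It stands to compound 3 as compound 2 stands to compound 1: the difference is 4-(trifluoromethyl)phenyl in place of 2-fluorophenyl on an aromatic carbon, and it sits at the same place, on an aromatic carbon of a six-membered aromatic ring with one nitrogen, meta to a large group and opposite the ring nitrogen. The cores of the two pairs differ by pyrrolidin-1-yl in place of piperidin-1-yl on a saturated chain carbon, three bonds along the chain from an oxygen on an aromatic ring, a change that left the measured value essentially unmoved. The account rests on one measured instance of the change, the step of a 2.8-fold higher number from compound 1 to compound 2 (0.44 log units; beyond the scatter). From that step the expected move is estimated as a 2.8-fold higher number from compound 3 to compound 4 (0.44 log units; beyond the scatter). On that basis compound 4 is expected to give about 390 nM in this assay, with a plausible range from 200 nM to 750 nM.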

Compound 4, half-maximal inhibitory concentration: 250 nM
Compound 4: middle estimate off by 1.6-fold (0.19 log units), on the high side; the range from low to high includes it.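

In this assay, the exchange of 2-fluorophenyl for 4-(trifluoromethyl)phenyl on the core of compound 3 reads as a 1.8-fold higher number from compound 3 to compound 4 (0.25 log units; within the scatter), and it cannot be told apart from the same exchange on the core of compound 1: the same change on two cores in this assay, a 2.8-fold higher number (0.44 log units; beyond the scatter) from compound 1 to compound 2 and a 1.8-fold higher number (0.25 log units; within the scatter) from compound 3 to compound 4, 1.6-fold (0.19 log units) apart, within the scatter of two such steps The exchange of piperidin-1-yl for pyrrolidin-1-yl also carries over between the two aryl groups, with a 1.4-fold lower number from compound 2 to compound 4 (0.16 log units; within the scatter) on the 4-(trifluoromethyl)phenyl compounds, again no different from the earlier step: the same change on two cores in this assay, a 1.1-fold higher number (0.03 log units; within the scatter) from compound 1 to compound 3 and a 1.4-fold lower number (0.16 log units; within the scatter) from compound 2 to compound 4, 1.6-fold (0.19 log units) apart, within the scatter of two such steps Each change is therefore consistent with carrying over from one core to the other in this small square of compounds, but that rests on a single pair of steps per change, and the aryl exchange lies beyond the scatter on one core and within it on the other, so a real weakening on the core of compound 3 is not established.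

The compounds shown leave open whether this holds with other amines at the end of the chain, such as morpholin-4-yl or dimethylamino, or with a shorter or longer chain. They also leave open how other aryl groups, such as unsubstituted phenyl or 4-methoxyphenyl, would behave at the same place.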